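This account rests on a few compounds, and the source may have more. Where it says the series, first, only, none or still open, it means among the compounds named here.

For the measured compounds named here, compound 2, `CC(O)(CSc1ccccc1)c1nc(-c2ccc(F)c(Cl)c2)no1`, gives the lower of the two numbers measured so far. In a functional assay on DU-145 cells (Homo sapiens) for cytotoxicity, read by MTT assay (on this read-out lower numbers stand for stronger inhibition and higher numbers for weaker inhibition), compound 2 gives 5500 nM, while compound 1, `CC(O)(CSc1ccc(Cl)cc1)c1nc(-c2ccccc2)no1`, gives 70700 nM; the gap between these two compounds lies beyond the usual scatter, but their structures differ in more than one place, so no single change can be tied to it. Compound 3, `CC(O)(CSc1ccc(Cl)cc1)c1nc(-c2ccc(F)c(Cl)c2)no1`, is the untested neighbour of compound 2. The change from compound 2 to compound 3 is chloro in place of hydrogen on an aromatic carbon, a chloro in place of hydrogen on an aromatic carbon of the phenylsulfanyl ring. Going by the values given here, no measured pair in this set isolates that change, so its effect cannot be read from the data. The expectation is that this step, a 1.4-fold lower number from compound 2 to compound 3 (0.14 log units; within the scatter), stays within or close to the scatter. Compound 3 is therefore estimated at 4000 nM, with a range from 1500 nM to 12000 nM.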

Compound 3, half-maximal inhibitory concentration: 500 nM
Beside the measured number, compound 3's estimate is 8.0-fold (0.90 log units) above it, and the stated range ends above it.
By their numbers in this assay, from the lowest: compound 3; then compound 2; then compound 1.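

In this assay, adding a chloro to the phenylsulfanyl ring, para to a large group, gives an 11-fold lower number from compound 2 to compound 3 (1.04 log units; beyond the scatter), the first shift in this set that can be tied to one single change. The other ring matters too: with that chloro kept in place, 3-chloro-4-fluorophenyl in place of phenyl gives a 140-fold lower number from compound 1 to compound 3 (2.15 log units; beyond the scatter), and compound 3 ends with the lowest number of the three. So both places respond strongly on this read-out, and the two changes together give the best result shown.

The compounds shown leave open whether chloro is special at the first place, or whether a methyl, a methoxy or an amine there would do the same, and whether the chloro or the fluoro carries the effect on the other ring. No measurement at hand gives a cause for either step.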